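Compound 3 and a Fluoro Swap in a Cell Toxicity Test

The source may hold more compounds than are shown below. What is called first, only, known or untested is meant among the compounds shown, and "the series" means these compounds.

Compound 1 (`COc1ccc(/C=C2\CN(Cc3cn(Cc4cccc(Cl)c4)nn3)C/C(=C\c3ccc(OC)cc3)C2=O)cc1`) reads > 100000 nM as a limit of the assay
Compound 2 (`COc1ccc(/C=C2\CN(Cc3cn(Cc4ccc(F)cc4)nn3)C/C(=C\c3ccc(OC)cc3)C2=O)cc1`) reads "not determined" (no result reported)
Compound 3 (`COc1ccc(/C=C2\CN(Cc3cn(Cc4ccccc4Cl)nn3)C/C(=C\c3ccc(OC)cc3)C2=O)cc1`) reads "not determined" (no result reported)

All three entries come from an ADME assay on HEK293 cells (Homo sapiens) for cytotoxicity, read by MTT assay, with a stated time of 24 h (a higher number here means a weaker inhibitor, a lower number a stronger inhibitor), and only compound 1 has a reported result. Compound 3 has no single number of its own, so its place can be told only through its relatives. For compound 1 the evidence is the limit of > 100000 nM in this assay, at which 1 of the 3 values shown sits, and that is a limit, not an exact number.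

The compound still waiting for measurement is compound 4 (`COc1ccc(/C=C2\CN(Cc3cn(Cc4ccccc4F)nn3)C/C(=C\c3ccc(OC)cc3)C2=O)cc1`) and it keeps the core shared by the others. The change is fluoro in place of chloro on an aromatic carbon and in words it is fluoro in place of chloro on an aromatic carbon, ortho to a large group, so 2-chlorobenzyl becomes 2-fluorobenzyl.

Within the data shown here, no pair of measured compounds shows what such a swap does in this assay and compound 3 offers no starting number, so no step beyond the usual scatter is expected. Among the measured compounds shown here, the only anchor is compound 1, whose > 100000 nM is a limit. Compound 4 is therefore expected to sit close to that limit, and it may well be reported only as a limit too. The estimated value for compound 4 is 90000 nM (expected range 40000 nM to 150000 nM).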

Compound 4, half-maximal inhibitory concentration: > 100000 nM
Compound 4: only a limit was reported (the forecaster's own chance of this, stated with the estimate: 80%); at least 1.1-fold (0.04 log units) between middle value and limit.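

Compound 1 and compound 4 each give only a limit in this assay, so the step between them cannot be read: the limit of > 100000 nM in this assay, at which 2 of the 4 values shown sit.

The compounds shown leave open what the change from 2-chlorobenzyl to 2-fluorobenzyl does in this assay, and at what exact concentration any of them would reach half-maximal inhibition.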